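The source may report more compounds than this note shows. Statements on the series, on what has been measured and on what is new or still open speak of the compounds shown alone.

Compound 1: `CCCC(CCC)n1c(-c2ccc(OCc3c(-c4c(Cl)cccc4Cl)noc3C(C)C)cc2)nc2ccc(C(=O)O)cc21` — 1.8 nM
Compound 2: `CC(C)c1onc(-c2c(Cl)cccc2Cl)c1COc1ccc(-c2nc3ccc(C(=O)O)cc3n2CC2CCCCC2)c(Cl)c1` — 7.6 nM

Both compounds were tested in an assay on Huh-7 cells for agonist activity at Bile acid receptor (Homo sapiens), read by a luciferase reporter; on this read-out lower numbers stand for an effect already at smaller amounts and higher numbers for an effect only at larger amounts of compound. Compound 1 has the lowest of the two numbers there; compound 2 lies at a clearly higher number, a gap beyond the usual scatter. Compound 3, `CC(C)c1onc(-c2c(Cl)cccc2Cl)c1COc1ccc(-c2nc3ccc(C(=O)O)cc3n2C2CCCC2)cc1`, has not yet been measured in this assay. Its difference from compound 1 is cyclopentyl in place of 1-propylbutyl on an aromatic nitrogen. Among the compounds with values here, no measured pair shows this change, so the size of the step is open. The account expects a modest loss of potency, a step of a 2.8-fold higher number from compound 1 to compound 3 (0.44 log units; beyond the scatter) from compound 1 to compound 3 that may or may not exceed the scatter. Compound 3 is estimated at 5 nM, within 1.5 nM to 20 nM.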

Compound 3, half-maximal effective concentration: 13.6 nM
For compound 3 the middle estimate is 2.7-fold (0.43 log units) below the measured one; low and high end bracket the measured number.
By their numbers in this assay, from the lowest: compound 1; then compounds 2 and 3 (each within the scatter of the next).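

In this assay, the aromatic nitrogen proves sensitive to the group it carries: cyclopentyl in place of 1-propylbutyl gives a 7.6-fold higher number from compound 1 to compound 3 (0.88 log units; beyond the scatter) and this change goes beyond the scatter. The two groups are both all carbon, so a change confined to carbon groups is enough to move the number at this position. Nothing available explains the step. This single pair cannot separate the presence of a ring from the smaller count of heavy atoms. As far as these compounds go, how an open pentyl chain or a piperidine ring would read at this nitrogen remains open.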